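A few compounds are considered here, and "the series" means these few. Any claim that something is new, unique, unknown or untested is made for them only; others in the source may bear on it.

Of the compounds shown here, three built on the same core have been measured in a functional assay on MCF7 cells (Homo sapiens) for antiproliferative activity, read by XTT assay, with a stated time of 72 h; on this read-out lower numbers stand for stronger inhibition and higher numbers for weaker inhibition. Compound 1 `COc1ccc(-c2cc3ccccc3nc2/C=C/C(=O)c2ccc(F)cc2)cc1` gives 5450 nM, and compound 2 `COc1ccc(-c2cc3ccccc3nc2/C=C/C(=O)c2ccc(OC)cc2OC)cc1` gives 6260 nM. Compound 3 `COc1ccc(-c2cc3ccccc3nc2/C=C/C(=O)c2sccc2N)cc1` reaches only the limit of this assay, > 10000 nM. Compound 4 `COc1ccc(-c2cc3ccccc3nc2/C=C/C(=O)c2cnc(N)nc2C)cc1` carries 2-amino-4-methylpyrimidin-5-yl in place of 3-aminothiophen-2-yl on a carbonyl carbon. Two measured steps change the group on that same carbonyl carbon and both end at compound 3: an at least 1.8-fold higher number from compound 1 to compound 3 (0.26 log units; that floor lies within the scatter) and an at least 1.5-fold higher number from compound 2 to compound 3 (0.20 log units; that floor lies within the scatter), each floor lying within the scatter. Nothing among these compounds shows a group on the carbonyl carbon lifting potency, so a similarly weak result is expected. The expected step is a step that the limit leaves unreadable from compound 3 to compound 4, that is, no change beyond the scatter. Compound 4 is estimated at 12000 nM, between 4000 nM and 35000 nM, with a fair chance that this assay again reports only a limit.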

Compound 4, half-maximal inhibitory concentration: > 10000 nM
Compound 4: only a limit was reported; the forecaster's own chance of this, stated with the estimate: 55%; the middle value does not contradict the limit.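

In this assay compound 4 gives only a limit, > 10000 nM. A six-membered 2-amino-4-methylpyrimidin-5-yl ring on the carbonyl carbon therefore gives no measurable gain over the five-membered 3-aminothiophen-2-yl ring, and the readable steps are an at least 1.5-fold higher number from compound 2 to compound 4 (0.20 log units; that floor lies within the scatter) and an at least 1.8-fold higher number from compound 1 to compound 4 (0.26 log units; that floor lies within the scatter). The step between the two amino-bearing compounds cannot be read, because both values are limits: the limit of > 10000 nM in this assay, at which 2 of the 4 values shown sit.

On these data alone, the actual values of compound 3 and compound 4 remain open. So does whether a 4-chlorophenyl or a plain phenyl group on the carbonyl carbon would differ from the 4-fluorophenyl of compound 1.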